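Swapping a Ring Nitrogen on the Sulfur-Linked Ethyl Group

This account rests on a few compounds, and the source may have more. Where it says the series, first, only, none or still open, it means among the compounds named here.

Compound 1 `Cn1ncc2c(=O)n(-c3ccccc3)c(SC(C)(C)c3ccccc3)nc21` gives 1900 nM in an assay on isolated protein for inhibition of aldehyde dehydrogenase 1A1 (Homo sapiens); on this read-out lower numbers stand for stronger inhibition and higher numbers for weaker inhibition.
Compound 2 `CC(Sc1nc2c(cnn2C)c(=O)n1-c1ccccc1)c1cncnc1` gives 94 nM in this assay.

In this assay compound 2 has the lowest number of the two; its nearest neighbour is compound 1, and the step of a 20-fold lower number from compound 1 to compound 2 (1.31 log units; beyond the scatter) lies beyond the scatter. Compound 3 `CC(Sc1nc2c(cnn2C)c(=O)n1-c1ccccc1)c1cccnc1` differs from compound 2 by pyridin-3-yl in place of pyrimidin-5-yl on a saturated chain carbon bound to a saturated chain carbon and a sulfur. Within the data shown here, the one measured step, a 20-fold lower number from compound 1 to compound 2 (1.31 log units; beyond the scatter), exchanged the entire sulfur-bound group at once, so it bears only loosely on this smaller change; no measured pair shows a single ring nitrogen removed on its own. The step of a 1.3-fold higher number from compound 2 to compound 3 (0.11 log units; within the scatter) is therefore expected to stay within the scatter. Compound 3 is estimated at 120 nM, between 40 nM and 400 nM.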

Compound 3, half-maximal inhibitory concentration in the aldehyde dehydrogenase 1A1 assay: 139 nM
Beside the measured number, compound 3's estimate is 1.2-fold (0.06 log units) below it; the range from low to high includes it.
By their numbers in the aldehyde dehydrogenase 1A1 assay, from the lowest: compounds 2 and 3 (each within the scatter of the next); then compound 1.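

In the aldehyde dehydrogenase 1A1 assay, taking one ring nitrogen away gives only a small step (a 1.5-fold higher number from compound 2 to compound 3 (0.17 log units; within the scatter)), so pyridin-3-yl and pyrimidin-5-yl cannot be told apart at this position, and the large gain over 1-methyl-1-phenylethyl remains (a 14-fold lower number from compound 1 to compound 3 (1.14 log units; beyond the scatter)). In a physicochemical assay for solubility, using the shake flask method, in phosphate buffer, with a stated time of 24 h, at pH 7.4 (on this read-out lower numbers stand for lower solubility and higher numbers for higher solubility), compound 2 gives 264000 nM and compound 3 gives 209000 nM, again no real difference (a 1.3-fold lower number from compound 2 to compound 3 (0.10 log units; within the scatter)). Nothing available gives a cause for these results.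

Still open, as far as these compounds go, is how far the large gain depends on any ring nitrogen at all, which a plain 1-phenylethyl group on the sulfur would help to settle.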